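Series notes: naphthylmethyl versus biphenylmethyl on the shared core

The compounds below may be only part of what the source reports. "The series", "measured", "known", "first", "only" and "open" are said of these compounds alone.

Measured so far:
- compound 1, `CC(C)C(c1nc(Cc2ccc3ccccc3c2)c(C(=O)O)[nH]1)N(C)S(=O)(=O)c1cc(Cl)cc(Cl)c1`: 2540 nM
- compound 2, `O=C(O)c1[nH]c(CN(C2CCCCC2)S(=O)(=O)c2cc(Cl)cc(Cl)c2)nc1Cc1ccc2ccccc2c1`: 285 nM

Two compounds carry numbers in an assay on Jurkat cells for displacement of a labelled ligand from integrin alpha-4 (Homo sapiens); a higher number here means a weaker inhibitor, a lower number a stronger inhibitor. Compound 1 gives 2540 nM. Compound 2 gives 285 nM, the lower of the two values, and the gap to compound 1 lies well beyond the scatter. Compound 1 and compound 2 differ in more than one place, so nothing is read from that pair about any single change.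

Compound 3, `O=C(O)c1[nH]c(CN(C2CCCCC2)S(=O)(=O)c2cc(Cl)cc(Cl)c2)nc1Cc1ccc(-c2ccccc2)cc1`, has not been measured in this assay. It differs from compound 2 in one place: 4-phenylphenyl in place of naphthalen-2-yl on a saturated chain carbon bound to an aromatic carbon. Both groups carry two six-membered aromatic rings of carbon only and neither adds a donor or an acceptor. No measured pair in this set tracks such an exchange, so the direction of the step rests on no shown number.

The expectation is a step no larger than the scatter or a modest weakening, a 1.4-fold higher number from compound 2 to compound 3 (0.15 log units; within the scatter), from compound 2 to compound 3. Compound 3 is estimated at 400 nM, with a range from 150 nM to 1100 nM.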

Compound 3, half-maximal inhibitory concentration: 237 nM
Estimate against measurement, compound 3: 1.7-fold (0.23 log units) above, within the range that was stated.
By their numbers in this assay, from the lowest: compounds 3 and 2 (each within the scatter of the next); then compound 1.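

In this assay the exchange of naphthalen-2-yl for 4-phenylphenyl on a saturated chain carbon bound to an aromatic carbon gives a 1.2-fold lower number from compound 2 to compound 3 (0.08 log units; within the scatter) and so leaves compound 2 and compound 3 indistinguishable. For the compounds shown here, this is the only single-place reading, as compound 1 and compound 2 differ in more than one place, and it shows that this place takes either group, each with two six-membered aromatic rings of carbon only, without a step beyond the scatter. No accompanying measurement bears on this exchange, and the result is left without an explanation.

The compounds shown leave open how far this tolerance extends, since every group at this place carries two six-membered aromatic rings of carbon only; a single phenyl ring, or a pyridin-3-yl ring with its ring nitrogen, would test whether both rings and an all-carbon ring system are needed. They also leave open whether the same exchange gives a similar step on the core of compound 1, which carries a different sulfonamide side chain.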